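A few compounds are considered here, and "the series" means these few. Any claim that something is new, unique, unknown or untested is made for them only; others in the source may bear on it.

Within the data shown here, compound 2, `O=c1c(O)c(-c2ccc(C(F)(F)F)cc2)oc2cc(OCc3ccc(Cl)cc3)cc(O)c12`, gives in an ADME assay on Huh-5-2 cells (Homo sapiens) for cytotoxicity, read by WST assay, with a stated time of 3 days (a higher number here means that more compound is tolerated, a lower number that less compound is tolerated), 73000 nM, the only plain number among the values shown. Compound 1, `O=c1c(O)c(-c2ccccc2)oc2cc(OCc3ccc(Cl)cc3)cc(O)c12`, sits at a limit of this assay, > 100000 nM; that limit is the limit of > 100000 nM in this assay, at which 1 of the 2 values shown sits. Among the measured compounds shown here, the one measured step is an at least 1.3-fold lower number from compound 1 to compound 2 (0.13 log units; that floor lies within the scatter). Compound 3, `COc1ccc(-c2oc3cc(OCc4ccc(Cl)cc4)cc(O)c3c(=O)c2O)cc1`, differs from compound 2 in one place: methoxy in place of trifluoromethyl on an aromatic carbon. Since that single step stays within the scatter, no change beyond the scatter is expected, and compound 3 is estimated at 90000 nM, between 40000 nM and 200000 nM, an expected step of a 1.2-fold higher number from compound 2 to compound 3 (0.09 log units; within the scatter).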

Compound 3, half-maximal cytotoxic concentration: 64000 nM
Compound 3: the middle estimate sits 1.4-fold (0.15 log units) above what was measured, within the range that was stated.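

At this position, methoxy, which brings a hydrogen-bond acceptor that trifluoromethyl lacks, gives a 1.1-fold lower number from compound 2 to compound 3 (0.06 log units; within the scatter) in this assay and so cannot be told apart from trifluoromethyl here. Against the unsubstituted phenyl, methoxy gives an at least 1.5-fold lower number from compound 1 to compound 3 (0.19 log units; that floor lies within the scatter) and this floor does not tell how large the real step is. Compound 1 stands at a limit and not at a number: the limit of > 100000 nM in this assay, at which 1 of the 3 values shown sits.

On these data alone, whether an amine or a carboxylic acid on this same aromatic carbon would also stay within the scatter remains open. So does the effect of a longer chain in place of methoxy.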